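The source may report more compounds than this note shows. Statements on the series, on what has been measured and on what is new or still open speak of the compounds shown alone.

Working notes on a small set of purine-like chlorides bearing a chloromethyl-benzyl arm. In a functional assay on SF-295 cells (Homo sapiens) for cytotoxicity, read by sulforhodamine B assay, with a stated time of 48 h (on this read-out higher numbers stand for weaker inhibition of growth and lower numbers for stronger inhibition of growth), compound 1 `ClCc1ccc(Cn2cnc3c(Cl)ncnc32)cc1` gives 270 nM. Compound 2 `Nc1nc(Cl)c2ncn(Cc3ccc(CCl)cc3)c2n1` is obtained from it by one change, (amino in place of hydrogen on an aromatic carbon), and in this assay compound 2 gives 10700 nM; the step is a 40-fold higher number from compound 1 to compound 2 (1.60 log units; beyond the scatter). Compound 3 `ClCc1ccccc1Cn1cnc2c(Cl)ncnc21` carries the same atoms as compound 1 joined differently; how the two cores differ is not broken down here. In this assay compound 3 gives 10500 nM, which sits within the scatter of compound 2 and well apart from compound 1.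

Compound 4 `Nc1nc(Cl)c2ncn(Cc3ccccc3CCl)c2n1` is not yet measured. Within the data shown here, it differs from compound 3 by amino in place of hydrogen on an aromatic carbon, the same change, at the same place, as the one made from compound 1 to compound 2. Among the measured compounds shown here, the only precedent for this change is the one step above, and it was made on a far stronger starting point. For compound 4 the expected step is a 3.8-fold higher number from compound 3 to compound 4 (0.58 log units; beyond the scatter), estimated smaller than the earlier one because compound 3 already stands at 10500 nM. The estimate for compound 4 in this assay is therefore 40000 nM, between 10000 nM and 200000 nM.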

Compound 4, concentration for 50% growth inhibition: 7410 nM
For compound 4 the middle estimate is 5.4-fold (0.73 log units) above the measured one, and the stated range ends above it.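

The change does not carry over as a fixed step from one core to the other in this assay: the same change on two cores in this assay, a 40-fold higher number (1.60 log units; beyond the scatter) from compound 1 to compound 2 and a 1.4-fold lower number (0.15 log units; within the scatter) from compound 3 to compound 4, 56-fold (1.75 log units) apart, beyond the scatter of two such steps. On the core of compound 3 the step is a 1.4-fold lower number from compound 3 to compound 4 (0.15 log units; within the scatter), so amino in place of hydrogen gives no readable change there, whereas the same change on the core of compound 1 gives a large one. This rests on two pairs only: it shows that the outcome depends on the core in these compounds, but it does not show what in the cores produces the gap, nor does it give a rule for any further core.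

The compounds shown leave open whether another group at that aromatic carbon, such as methylamino or hydroxyl, would also separate the two cores. They also leave open whether the chloromethyl group itself matters, as a methyl or hydroxymethyl group in its place on the arm of compound 1, which gives 270 nM, would test.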